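Geometry of an exocyclic double bond and cell tolerance

A few compounds are considered here, and "the series" means these few. Any claim that something is new, unique, unknown or untested is made for them only; others in the source may bear on it.

The account concerns two measured nucleobase-bearing cyclopropylidene diols and one isomer of the first that has not yet been measured. Compound 1 `Nc1ncnc2c1ncn2/C=C1\C[C@@H]1[C@H](O)CO` was tested in an ADME assay on Akata cells (Homo sapiens) for cytotoxicity (a higher number here means that more compound is tolerated, a lower number that less compound is tolerated), and gives 57000 nM. Its companion, compound 2 `Nc1nc2c(ncn2/C=C2\C[C@H]2[C@@H](O)CO)c(=O)[nH]1`, gives 75000 nM in this assay. Compound 1 holds the lowest of the two numbers recorded, and its nearest neighbour is compound 2, whose number is only modestly higher; the two values lie within the scatter of each other, so nothing can be said about an order between them.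

The unmeasured compound 3 `Nc1ncnc2c1ncn2/C=C1/C[C@@H]1[C@H](O)CO` is the geometric isomer of compound 1. The difference between them is the two compounds have the same atoms and bonds and differ only in configuration as drawn: 1 of 3 stereo elements differ; a double bond is drawn E in compound 1 and Z in compound 3. Going by the values given here, no measured pair in this set differs in only this way, so there is no recorded step to lean on. Because compound 1 gives 57000 nM and compound 2 gives a value within the scatter of it, the account expects no step beyond the scatter for a 1.1-fold lower number from compound 1 to compound 3 (0.06 log units; within the scatter). Compound 3 is therefore estimated at 50000 nM in this assay, with a plausible range from 15000 nM to 160000 nM.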

Compound 3, half-maximal cytotoxic concentration: 50500 nM
Beside the measured number, compound 3's estimate is 1.0-fold (0.00 log units) below it; measured number inside the range.
By their numbers in this assay, from the lowest: compounds 3, 1 and 2 (each within the scatter of the next).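

Going by these compounds alone, the pair gives the first recorded step at the exocyclic double bond: in this assay there is a 1.1-fold lower number from compound 1 to compound 3 (0.05 log units; within the scatter). Before this, no measured pair differed in this way alone, so the two earlier compounds could say nothing about the drawn geometry taken by itself. At this double bond, going from E to Z brings no difference beyond the scatter in how much compound the cells tolerate, and the reading concerns geometry alone, with no other structural change mixed in: the fact that compounds 1 and 3 differ only in the configuration as drawn

What the compounds shown leave open is whether the same indifference to double bond geometry holds with the nucleobase of compound 2, or whether the other two stereo elements of compound 1 are equally without consequence in this assay. They also do not tell how tolerance would respond if an amine or a carboxylic acid stood in place of the diol, or if a longer chain carried it.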